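The compounds below may be only part of what the source reports. "The series", "measured", "known", "first", "only" and "open" are said of these compounds alone.

Measured so far:
Compound 1, `CC(C)OC(=O)N1CCC(Oc2cccc3c2CCN3c2ccc(S(C)(=O)=O)cc2)CC1` — in a functional assay on CHO-K1 cells with Glucose-dependent insulinotropic receptor (Homo sapiens) as the target, read by a luciferase reporter, with a stated time of 5 h (on this read-out lower numbers stand for smaller maximal responses and higher numbers for larger maximal responses), compound 1 gives 70%.
Compound 2, `CC(C)(C)OC(=O)N1CCC(Oc2cccc3c2ccn3-c2ccc(S(C)(=O)=O)cc2)CC1` — in this assay compound 2 gives 28%.
Compound 3, `COC(=O)N1CCC(Oc2ncnc3c2CCN3c2ccc(S(C)(=O)=O)cc2F)CC1` — in this assay compound 3 gives 119%.

Compound 3 stands highest of the three. Compound 1 lies nearest to it, with a maximal response well below that of compound 3 and beyond the usual scatter; compound 2 lies furthest away, also beyond the scatter. Among the compounds with values here, the three compounds differ from one another in more than one place, so no single step between them can be isolated; the values alone show that compound 3 reaches the largest maximal response of the set.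

The next compound, compound 4, `CS(=O)(=O)c1ccc(N2CCc3c(OC4CCN(C(=O)OCCF)CC4)ncnc32)c(F)c1`, differs from compound 3 in one place only: fluoromethyl in place of hydrogen on a saturated chain carbon bound to an oxygen next to a carbonyl group. Taken one bond further out, the methoxycarbonyl of compound 3 becomes (2-fluoroethoxy)carbonyl in compound 4. The carbamate ester in compounds 1 and 2 is larger than that of compound 3, but those compounds also carry different cores, so nothing measured isolates the effect of the ester group alone. Within the data shown here, with no comparable step in hand, the step from compound 3 to compound 4 in this assay is expected to be small, if anything a modest decrease, and may lie within the scatter.

The maximal response of compound 4 in this assay is expected at 105%, within a range of 75% to 130%. This expectation corresponds to the step of a number 14 percentage points lower from compound 3 to compound 4 (beyond the scatter).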

Compound 4, largest response reached (reported as percent of maximum), in percent of the reference or control that the assay uses: 86%
Compound 4: the middle estimate sits 19 percentage points above what was measured; measured number inside the range.
By their numbers in this assay, from the lowest: compound 2; then compound 1; then compound 4; then compound 3.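

In this assay, the ester end of the carbamate proves sensitive to a small change: methyl to 2-fluoroethyl comes with a number 33 percentage points lower from compound 3 to compound 4 (beyond the scatter) on an otherwise unchanged structure. Within the data shown here, this is the first step that isolates the ester group, which compounds 1 and 2 could not do, as their cores differ as well. Nothing on hand accounts for the drop, so it stands as an observation only.

On these data alone, it remains open whether the fluorine or the longer chain carries this step, and an ethyl ester on the core of compound 3 would separate the two. A 2-methoxyethyl or 2-hydroxyethyl ester at the same place would show whether the maximal response falls with other groups at the end of the chain.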